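The source may report more compounds than this note shows. Statements on the series, on what has been measured and on what is new or still open speak of the compounds shown alone.

Measured so far:
compound 1, `COc1cc(-n2ncnc2-c2ccc(OC(C)C)cc2)cc(OC)c1OC`: 610 nM
compound 2, `COc1cc(-n2ncnc2-c2ccc(C)cc2)cc(OC)c1OC`: 540 nM

In a functional assay on MCF7 cells (Homo sapiens) for antiproliferative activity, read by MTT assay, with a stated time of 72 h (a lower number here means a stronger inhibitor, a higher number a weaker inhibitor), compound 2 and compound 1 give values that lie within the usual scatter of each other, as the step of a 1.1-fold lower number from compound 1 to compound 2 (0.05 log units; within the scatter) shows. Compound 3, `COc1cc(-n2ncnc2-c2cccc(Cl)c2)cc(OC)c1OC`, carries 3-chlorophenyl in place of 4-methylphenyl on an aromatic carbon. Among the measured compounds shown here, the only measured step, a 1.1-fold lower number from compound 1 to compound 2 (0.05 log units; within the scatter), changed the group on the same ring and stayed within the scatter, so no step beyond the scatter is expected in this assay for compound 3 either. The expected step is a 1.0-fold higher number from compound 2 to compound 3 (0.02 log units; within the scatter). Compound 3 is estimated at 560 nM, with a range from 250 nM to 1300 nM.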

Compound 3, half-maximal inhibitory concentration: > 10000 nM
Compound 3 gave a limit, no number; the forecaster's own chance of this, stated with the estimate: 3%; middle value at least 17-fold (1.25 log units) from the limit.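

In this assay the swap gives an at least 18-fold higher number from compound 2 to compound 3 (1.26 log units; beyond the scatter), so this position does not accept every change, as the small step between compound 1 and compound 2 might have suggested. Compound 3 gives a limit of the assay, not a number: the limit of > 10000 nM in this assay, at which 1 of the 3 values shown sits. The swap from 4-methylphenyl to 3-chlorophenyl changes both the group on the phenyl ring and where it sits, and these two changes cannot be separated here.

Going by these compounds, whether the chlorine or its new place matters more stays open. A 4-chlorophenyl or a 3-methylphenyl group at this position would help to separate the two.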